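The source may hold more compounds than are shown below. What is called first, only, known or untested is meant among the compounds shown, and "the series" means these compounds.

Compound 1: `CCCS(=O)(=O)Nc1ccc(F)c(C(=O)c2n[nH]c3ncc(-c4ccc(N)cc4)cc23)c1F`, 3.7%.
Compound 2: `CCCS(=O)(=O)Nc1ccc(F)c(C(=O)c2n[nH]c3ncc(-c4ccc(S(=O)(=O)NCC)cc4)cc23)c1F`, 41%.

Going by the values given here, in an assay for binding affinity to dual specificity mitogen-activated protein kinase kinase 4 (Homo sapiens), read by KINOMEscan, tested at 10 nM (a higher number here means a weaker effect of the compound at the concentration tested, a lower number a stronger effect), compound 2 gives 41%, the highest of the two numbers, while compound 1 gives 3.7%; the only measured step, a number 37.3 percentage points higher from compound 1 to compound 2 (beyond the scatter), lies between them. Compound 3 is `CCCS(=O)(=O)Nc1ccc(F)c(C(=O)c2n[nH]c3ncc(-c4ccc(NS(C)(=O)=O)cc4)cc23)c1F`. It differs from compound 2 in one place: methanesulfonamido in place of ethylsulfamoyl on an aromatic carbon. The entering methanesulfonamido is joined to the ring through its nitrogen, as the amino of compound 1 is, whereas the leaving ethylsulfamoyl is joined through its sulfur. Only a number 37.3 percentage points higher from compound 1 to compound 2 (beyond the scatter) bears on this change, and only indirectly, so the direction is uncertain; a move part of the way back toward the number of compound 1 is expected, a number 26 percentage points lower from compound 2 to compound 3 (beyond the scatter). Compound 3 is therefore estimated at 15%, with a range from 3% to 45%.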

Compound 3, a percentage reported as activity, at one concentration (the size of the read-out at that concentration, not a potency): 16%
For compound 3 the middle estimate is 1 percentage points below the measured one; the measured number falls inside the stated range.
By their numbers in this assay, from the lowest: compound 1; then compound 3; then compound 2.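

In this assay, the step of a number 25 percentage points lower from compound 2 to compound 3 (beyond the scatter) shows that this position distinguishes between two groups with the same counts of hydrogen-bond donors and acceptors, one joined to the ring through sulfur and the other through nitrogen. The step of a number 12.3 percentage points higher from compound 1 to compound 3 (beyond the scatter) adds that placing methylsulfonyl on the amino nitrogen gives a higher number, though compound 3 still lies between compound 1 and compound 2. Nothing available explains these differences in the number.

The change from compound 2 to compound 3 alters both the joining atom and the chain, from ethyl to methyl, so the compounds shown cannot separate the two effects. An ethanesulfonamido group would address that question, while an acetamido group would test whether the sulfonyl part matters on this nitrogen.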